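Methyl for Isopropyl: Expecting the Step a Second Time

The source may report more compounds than this note shows. Statements on the series, on what has been measured and on what is new or still open speak of the compounds shown alone.

The measured compounds and their values:
Compound 1 `CC(C)[C@H](NC(=S)NCc1ccccc1)c1nc2ccccc2[nH]1` gives 48500 nM.
Compound 2 `CC(C)[C@@H](NC(=S)Nc1cc(C(F)(F)F)cc(C(F)(F)F)c1)c1nc2ccccc2[nH]1` gives 20200 nM.
Compound 3 `C[C@H](NC(=S)NCc1ccccc1)c1nc2ccccc2[nH]1` gives 226000 nM.

All three were tested in a functional assay on DU-145 cells (Homo sapiens) for cytotoxicity, read by MTT assay; a higher number here means a weaker inhibitor, a lower number a stronger inhibitor. Compound 2 has the lowest number of the three; compound 1 stands nearest to it, and compound 3 furthest. The difference between the core of compound 1 and the core of compound 2 is not broken down here.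

One structural change has already been measured once: from compound 1 to compound 3 the change is methyl in place of isopropyl on a saturated chain carbon bound to an amide-type nitrogen and an aromatic carbon. That change produced a 4.7-fold higher number from compound 1 to compound 3 (0.67 log units; beyond the scatter), a modest loss of potency that lies beyond the scatter.

Compound 4 `C[C@@H](NC(=S)Nc1cc(C(F)(F)F)cc(C(F)(F)F)c1)c1nc2ccccc2[nH]1` has not yet been measured. It differs from compound 2 by methyl in place of isopropyl on a saturated chain carbon bound to an amide-type nitrogen and an aromatic carbon, the same change as from compound 1 to compound 3, made at the same kind of place on the chain. Going by the values given here, since the only measured example of this change, from compound 1 to compound 3, gave a 4.7-fold higher number from compound 1 to compound 3 (0.67 log units; beyond the scatter), the step from compound 2 to compound 4 in this assay is expected to be of similar size, a 4.7-fold higher number from compound 2 to compound 4 (0.67 log units; beyond the scatter), though a single pair is a thin basis and the starting points differ in the group on the thiourea nitrogen.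

Compound 4 is therefore estimated at 95000 nM, expected to fall between 40000 nM and 250000 nM.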

Compound 4, half-maximal inhibitory concentration: 17600 nM
The estimate for compound 4 lay 5.4-fold (0.73 log units) above the measured number, outside the stated range (below it).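

In this assay, methyl in place of isopropyl on a saturated chain carbon bound to an amide-type nitrogen and an aromatic carbon did not behave on the core of compound 2 as it had on the core of compound 1; the new step reads a 1.1-fold lower number from compound 2 to compound 4 (0.06 log units; within the scatter), so on this core the smaller group leaves the number within the scatter. The size of this step therefore did not carry from one core to the other, and the earlier result cannot be applied to every core in this series: the same change on two cores in this assay, a 4.7-fold higher number (0.67 log units; beyond the scatter) from compound 1 to compound 3 and a 1.1-fold lower number (0.06 log units; within the scatter) from compound 2 to compound 4, 5.3-fold (0.73 log units) apart, beyond the scatter of two such steps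

These two pairs show that the outcome of the change can depend on the core, but they do not show which feature of the cores decides it, or which of the two outcomes would be the more usual on a further core.

Going by these compounds, it remains open whether an ethyl group or a longer chain in place of the isopropyl would follow the pattern of compound 1 and compound 3 or that of compound 2 and compound 4. On these data alone, it also remains open how the change would read on a third core, for example one with a pyridine or a carboxylic acid in the group on the thiourea nitrogen.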